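This account rests on a few compounds, and the source may have more. Where it says the series, first, only, none or still open, it means among the compounds named here.

In a physicochemical assay for lipophilicity, read by HPLC, in phosphate buffer, measured as chromatographic lipophilicity, at pH 7.4 (on this read-out higher numbers stand for higher lipophilicity and lower numbers for lower lipophilicity), three compounds of one family have been measured so far. Compound 1 `Cc1cc(C)cc(NC(=O)COc2cc(C)nc3ccc(OC(F)(F)F)cc23)c1` gives 6.79. Compound 2 `COc1cccc(NC(=O)COc2cc(C)nc3ccc(OC)cc23)c1` gives 4.49, and compound 3 `COc1ccc2nc(C)cc(OCC(=O)Nc3cc(OC)c(OC)c(OC)c3)c2c1` gives 3.95. Among these three numbers compound 2 stands second highest: compound 3 lies lower than it, beyond the usual scatter, and compound 1 lies higher, also beyond the scatter. Compound 4 `COc1ccc2nc(C)cc(OCC(=O)Nc3ccncc3)c2c1` has not yet been measured. It differs from compound 2 in a single place: pyridin-4-yl in place of 3-methoxyphenyl on an amide-type nitrogen. Among the compounds with values here, no measured pair shows this exact change, so its size is not known from the data. The change is expected to lower the number clearly, beyond the scatter, with a step of a number 1.59 log units lower from compound 2 to compound 4 (beyond the scatter). On that basis compound 4 is estimated to give about 2.9, within a range from 2.2 to 3.6.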

Compound 4, distribution coefficient: 2.5
For compound 4 the middle estimate is 0.40 log units above the measured one; the measured number falls inside the stated range.
By their numbers in this assay, from the lowest: compound 4; then compound 3; then compound 2; then compound 1.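

In this assay, the group on the amide-type nitrogen now has a measured effect: pyridin-4-yl in place of 3-methoxyphenyl gives a number 1.99 log units lower from compound 2 to compound 4 (beyond the scatter) and so counts as a large step. Within the data shown here, this is the first pair that differs in this one place, so the size of a change here is now known from data. Nothing available explains why the step has this size. This change both puts a nitrogen into the ring and removes the methoxy group, and the compounds shown do not separate the two. On these data alone, how a plain phenyl group or a pyridin-3-yl group on the same nitrogen would read stays open.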